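The compounds below may be only part of what the source reports. "The series", "measured", "known", "first", "only" and "open" are said of these compounds alone.

In a physicochemical assay for solubility, in phosphate buffer, at pH 7.4 (a higher number here means a more soluble compound, a lower number a less soluble compound), compound 1 `CCOC(=O)c1c(-c2ccccc2)[nH]c2cc(OC)ccc2c1=O` gives > 100000 nM, which is a limit of the assay and not a number. For the measured compounds named here, compound 2 `CCOC(=O)c1c(-c2ccc(C(C)(C)C)cc2)[nH]c2cc(OC)ccc2c1=O` gives 2000 nM, the only actual number so far.

Compound 3 `CCOC(=O)c1c(-c2ccc(C(F)(F)F)cc2)[nH]c2cc(OC)ccc2c1=O` changes the same aromatic carbon that separates the first two compounds: trifluoromethyl in place of tert-butyl on an aromatic carbon, para to a large group (trifluoromethyl in place of tert-butyl on an aromatic carbon).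

Going by the values given here, only one measured step bears on this change, tert-butyl in place of hydrogen on an aromatic carbon. It is an at least 50-fold lower number from compound 1 to compound 2 (1.69 log units; beyond the scatter), a large step beyond the scatter. Among the compounds with values here, no measured compound carries trifluoromethyl, so the expectation rests on that single step and is uncertain. Taking out the tert-butyl is expected to recover a small part of that step, because compound 2 sits at 2000 nM after it, while a group of similar size remains at that carbon.

The expected change in this assay is a 2.5-fold higher number from compound 2 to compound 3 (0.40 log units; beyond the scatter), towards a higher number. For compound 3 the estimated value is 5000 nM, with an expected range of 1500 nM to 20000 nM.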

Compound 3, solubility: 8000 nM
Beside the measured number, compound 3's estimate is 1.6-fold (0.20 log units) below it; the measured number falls inside the stated range.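

In this assay, this aromatic carbon now gives a comparison between two actual numbers, and the identity of the group matters even with the heavy-atom count unchanged: a 4.0-fold higher number from compound 2 to compound 3 (0.60 log units; beyond the scatter). Trifluoromethyl also stays well on the lower side of the unsubstituted compound, so the drop seen with tert-butyl is not unique to that group: an at least 12-fold lower number from compound 1 to compound 3 (1.09 log units; beyond the scatter). For the compounds shown here, the value for compound 1 is a limit of the assay and not a number, so the full size of each step from hydrogen remains unknown, and only the step between compound 2 and compound 3 has a defined size: the limit of > 100000 nM in this assay, at which 1 of the 3 values shown sits.

On these data alone, whether an amine, a carboxylic acid, a methoxy group or a single fluorine on this same carbon would give a number closer to that of compound 3 or to the limit of compound 1 remains open. As far as these compounds go, all three compounds keep the ethyl ester and the methoxy group on the shared core, so the response of this assay to a carboxylic acid or an amide in place of that ester also remains open.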